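Nitro for Methoxy: Expected Growth Inhibition of Compound 4

The source may report more compounds than this note shows. Statements on the series, on what has been measured and on what is new or still open speak of the compounds shown alone.

Compound 1 `C#CCOc1ccc(/C=C/C(=O)c2ccc(OC)cc2)cc1` and compound 2 `C#CCOc1ccc(/C=C/C(=O)c2ccc([N+](=O)[O-])cc2)cc1` share one core. In a functional assay on A549 cells (Homo sapiens) for inhibition, read by MTT assay, with a stated time of 48 h, tested at 10 uM (on this read-out higher numbers stand for more inhibition of growth at the one concentration tested and lower numbers for less inhibition of growth), compound 1 gives 27%, and compound 2 gives 33%. The change nitro in place of methoxy on an aromatic carbon thus made a step of a number 6 percentage points higher from compound 1 to compound 2 (within the scatter). Compound 3 `COc1ccc(C(=O)/C=C/c2ccc(OCc3cn(Cc4ccccc4)nn3)cc2)cc1` is built on a different core; the difference between the two cores is not broken down here. In this assay compound 3 gives 44%, the highest of the three measured numbers. Compound 4 `O=C(/C=C/c1ccc(OCc2cn(Cc3ccccc3)nn2)cc1)c1ccc([N+](=O)[O-])cc1` differs from compound 3 by nitro in place of methoxy on an aromatic carbon, the same change, at the same place, as that seen between compound 1 and compound 2. Resting on a number 6 percentage points higher from compound 1 to compound 2 (within the scatter), a similarly small step is expected, a number 5 percentage points higher from compound 3 to compound 4 (within the scatter). Compound 4 is accordingly estimated at 49%, with a range from 36% to 62%.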

Compound 4, percent growth inhibition at one concentration: "not active" (no number reported)
No number was reported for compound 4; no gap can be computed for the estimate.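

Within the data shown here, compound 4 was reported as "not active" with no number, and no step from compound 3 to compound 4 can be read. The compounds shown leave open how nitro in place of methoxy acts on this core. Nothing available bears on this result.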